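Replacing furan-3-yl with 4-acetamidophenyl in compound 3

This account rests on a few compounds, and the source may have more. Where it says the series, first, only, none or still open, it means among the compounds named here.

Compound 1, `O[C@H]1Cc2ccccc2C1NC1CCN(CCCc2c[nH]c3ccc(-n4cnnc4)cc23)CC1`: 300 nM
Compound 2, `O[C@@H]1Cc2ccccc2[C@H]1NC1CCN(CCCc2c[nH]c3ccc(-n4cnnc4)cc23)CC1`: 210 nM
Compound 3, `c1cc(CNC2CCN(CCCc3c[nH]c4ccc(-n5cnnc5)cc34)CC2)co1`: 78 nM

In an assay on CHO cells for displacement of a labelled ligand from 5-hydroxytryptamine receptor 1B (Homo sapiens) (a higher number here means a weaker inhibitor, a lower number a stronger inhibitor), compound 3 has the lowest number of the three, separated from compound 2 by a 2.7-fold lower number from compound 2 to compound 3 (0.43 log units; beyond the scatter) and from compound 1 by a 3.8-fold lower number from compound 1 to compound 3 (0.59 log units; beyond the scatter). Compound 4, `CC(=O)Nc1ccc(CNC2CCN(CCCc3c[nH]c4ccc(-n5cnnc5)cc34)CC2)cc1`, differs from compound 3 by 4-acetamidophenyl in place of furan-3-yl on a saturated chain carbon bound to an amine nitrogen. Among the measured compounds shown here, no measured step changes this part of the molecule in the same way. The two steps leading to compound 3 show that exchanging the group on the amine nitrogen moves the number only modestly, and both went in the same direction. For compound 4 a small step is therefore expected, a 1.3-fold lower number from compound 3 to compound 4 (0.11 log units; within the scatter), possibly within the scatter. Compound 4 is estimated at 60 nM, with a range from 15 nM to 250 nM.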

Compound 4, half-maximal inhibitory concentration: 45 nM
The estimate for compound 4 lay 1.3-fold (0.12 log units) above the measured number; low and high end bracket the measured number.
By their numbers in this assay, from the lowest: compounds 4 and 3 (each within the scatter of the next); then compounds 2 and 1 (each within the scatter of the next).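

On the saturated chain carbon bound to an amine nitrogen, 4-acetamidophenyl, a larger group with a hydrogen-bond donor that furan-3-yl lacks, leaves the number in this assay essentially unchanged, with a 1.7-fold lower number from compound 3 to compound 4 (0.24 log units; within the scatter). Compared with the 2-hydroxy-2,3-dihydro-1H-inden-1-yl group, 4-acetamidobenzyl gives a 4.7-fold lower number from compound 2 to compound 4 (0.67 log units; beyond the scatter) and a 6.7-fold lower number from compound 1 to compound 4 (0.82 log units; beyond the scatter), both in the same direction as for (furan-3-yl)methyl. Nothing measured here bears on the reason for these results.

On these data alone, what a plain benzyl, or a benzyl carrying a carboxylic acid in place of the acetamido group, would give remains open. The part played by the acetamido group itself therefore cannot be told.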